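The source may hold more compounds than are shown below. What is called first, only, known or untested is meant among the compounds shown, and "the series" means these compounds.

Of the compounds shown here, two have been measured in an assay on isolated protein for inhibition of Retinaldehyde dehydrogenase 3 (Homo sapiens); a higher number here means a weaker inhibitor, a lower number a stronger inhibitor. Compound 1, `CC(C)C(Sc1nc2c(cnn2C)c(=O)n1-c1ccccc1)c1ccccc1`, gives 130 nM in this assay. Compound 2, `O=c1c2cncn2nc(SCc2cccc(F)c2)n1-c1ccccc1`, gives 500 nM in this assay. Of these two numbers compound 1 holds the lower one, and its gap to compound 2 lies beyond the usual scatter, so compound 1 is the stronger inhibitor of the pair.

Compound 3, `CC(Sc1nc2c(cnn2C)c(=O)n1-c1ccccc1)c1ccccc1`, has not yet been measured in this assay. It differs from compound 1 in one place: methyl in place of isopropyl on a saturated chain carbon bound to an aromatic carbon and a sulfur. The rest of the molecule, including the shared core, is kept unchanged.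

For the measured compounds named here, no pair of measured compounds differs in just this place, so there is no measured step to lean on, and compound 2 differs from compound 1 in several places at once, so its value says nothing direct about this change. The step from compound 1 to compound 3 is expected to be small and toward a weaker inhibitor, a 1.9-fold higher number from compound 1 to compound 3 (0.28 log units; within the scatter), possibly no larger than the scatter. Compound 3 is therefore estimated at 250 nM, within a range of 80 nM to 800 nM.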

Compound 3, half-maximal inhibitory concentration: 73 nM
Estimate against measurement, compound 3: 3.4-fold (0.53 log units) above; measured number below the stated range.
By their numbers in this assay, from the lowest: compounds 3 and 1 (each within the scatter of the next); then compound 2.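

Going from isopropyl to methyl on the saturated chain carbon bound to an aromatic carbon and a sulfur gives a 1.8-fold lower number from compound 1 to compound 3 (0.25 log units; within the scatter) in this assay for this single change. For the compounds shown here, this pair offers the first direct reading at this position, which the earlier compounds could not give, since compound 1 and compound 2 differ in several places at once. Within the precision of the assay, the position accepts both the branched isopropyl and the much smaller methyl with no real difference in inhibition, and nothing measured here bears on why the two groups read alike.

As far as these compounds go, two groups say little about the full reach of this position, so it remains open whether a bare hydrogen, a longer chain, an amine or a carboxylic acid on this carbon would also read alike or would shift the number clearly. From the compounds shown here alone, it is also open whether the same swap from isopropyl to methyl would read alike on the core of compound 2, where the rest of the molecule is different.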